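The source may hold more compounds than are shown below. What is called first, only, known or untested is meant among the compounds shown, and "the series" means these compounds.

Measured compounds:
compound 1, `CCSC1=N[C@@H](C(=O)OC)[C@@H]2C(=O)N(c3ccccc3)C(=O)[C@H]12`, 91%
compound 2, `COC(=O)[C@H]1N=C(SC)[C@H]2C(=O)N(c3ccccc3)C(=O)[C@H]21`, 84%
compound 3, `CCCCSC1=N[C@@H](C(=O)OC)[C@@H]2C(=O)N(c3ccccc3)C(=O)[C@H]12`, 82%

For the measured compounds named here, in a functional assay for inhibition, tested at 100 uM (a lower number here means less inhibition, a higher number more inhibition at the concentration tested (going by the name of the read-out)), compound 1 gives the highest of the three numbers, but neither of the others is separated from it by more than the scatter: compound 2 sits a number 9 percentage points lower from compound 1 to compound 3 (within the scatter) apart in kind only by comparison, and the one counted step, a number 9 percentage points lower from compound 1 to compound 3 (within the scatter), is within the scatter. So on the numbers shown the three compounds are indistinguishable in this assay.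

Compound 4, `COC(=O)[C@@H]1N=C(SC)[C@H]2C(=O)N(c3ccccc3)C(=O)[C@H]21`, is not yet measured. Relative to compound 1 the change is hydrogen in place of methyl on a saturated chain carbon bound to a sulfur. Going by the values given here, the one measured step that bears on the sulfur-bound chain, a number 9 percentage points lower from compound 1 to compound 3 (within the scatter), lengthened that chain without a change beyond the scatter. Shortening it is the opposite move on the same position, and compound 2, which also carries a methylsulfanyl group, gives 84%, again within the scatter of compound 1. The change is therefore expected to give no step beyond the scatter, with the expected step written as a number 5 percentage points lower from compound 1 to compound 4 (within the scatter).

The estimate for compound 4 in this assay is 86%, with a range from 74% to 96%.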

Compound 4, a percentage reported as inhibition, at one concentration (the size of the read-out at that concentration, not a potency): 93%
Compound 4: the middle estimate sits 7 percentage points below what was measured, and the stated range covers the measured number.
By their numbers in this assay, from the lowest: compounds 3, 2, 1 and 4 (each within the scatter of the next, the first and the last beyond it).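

In this assay, methylsulfanyl in place of ethylsulfanyl leaves the read-out unchanged within the scatter, a number 2 percentage points higher from compound 1 to compound 4 (within the scatter), so shortening this sulfur-bound chain shows no measurable loss of inhibition at the concentration tested. For the compounds shown here, the pair with the longest and shortest chains gives the only step in the set beyond the scatter, a number 11 percentage points higher from compound 3 to compound 4 (beyond the scatter), but it is modest, and compound 1 stays within the scatter of both, so no graded chain-length trend can be claimed. A stereocentre at a saturated ring carbon also gets its first reading, a number 9 percentage points higher from compound 2 to compound 4 (within the scatter), which is within the scatter and is a clean test of that one centre: the fact that compounds 2 and 4 differ only in the configuration as drawn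

From the compounds shown here alone, all of these numbers come from a single concentration, so whether the compounds differ in potency remains open, and the high numbers leave little room to separate them. Also open, going by these compounds, is how a terminal amine or a carboxylic acid on the sulfur-bound chain, or a chain longer than any of these, would behave, along with the effect of the other two stereo elements.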